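Removing the Bromo Group from the Phenol Ring

The compounds below may be only part of what the source reports. "The series", "measured", "known", "first", "only" and "open" are said of these compounds alone.

Measured compounds:
compound 1, `C=C1C[C@]23C[C@@]1(O)CC[C@H]2c1ccc(O)c(C)c1[C@@H]3Cn1cc(-c2ccccn2)nn1`: > 20000 nM (a limit)
compound 2, `C=C1C[C@]23C[C@@]1(O)CC[C@H]2c1ccc(O)c(C)c1[C@@H]3Cn1cc(-c2ccc(C(F)(F)F)cc2)nn1`: 8950 nM
compound 3, `C=C1C[C@]23C[C@@]1(O)CC[C@H]2c1cc(Br)c(O)c(C)c1[C@@H]3Cn1cc(-c2ccc(F)cc2)nn1`: 6600 nM

In a functional assay on HL-60 cells (Homo sapiens) for cytotoxicity, read by MTT assay, with a stated time of 4 days (on this read-out higher numbers stand for weaker inhibition and lower numbers for stronger inhibition), compound 1 gives > 20000 nM, which is a limit of the assay and not a number. Compound 2 gives 8950 nM. Compound 3 gives 6600 nM, the lowest of the two numbers, though its gap to compound 2 lies within the scatter. Within the data shown here, the only measured step, an at least 2.2-fold lower number from compound 1 to compound 2 (0.34 log units; beyond the scatter), concerns the aromatic group on the triazole and not the site changed here. Compound 4, `C=C1C[C@]23C[C@@]1(O)CC[C@H]2c1ccc(O)c(C)c1[C@@H]3Cn1cc(-c2ccc(F)cc2)nn1`, differs from compound 3 in one way: hydrogen in place of bromo on an aromatic carbon. Among the measured compounds shown here, no measured step bears on this change, so the step of a 1.1-fold higher number from compound 3 to compound 4 (0.06 log units; within the scatter) is expected to stay within the scatter. For compound 4 the estimated value is 7500 nM, expected to fall between 3000 nM and 20000 nM.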

Compound 4, half-maximal inhibitory concentration: > 20000 nM
Compound 4 ended at the assay's limit (the forecaster's own chance of this, stated with the estimate: 12%); middle value at least 2.6-fold (0.42 log units) away from the limit.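

Hydrogen in place of bromo, ortho to the hydroxy group, gives an at least 3.0-fold higher number from compound 3 to compound 4 (0.48 log units; beyond the scatter), so this position, which the earlier compounds left untested, affects the read-out. With hydrogen at this position, the substituent on the outer phenyl ring also counts: fluoro in place of trifluoromethyl gives an at least 2.2-fold higher number from compound 2 to compound 4 (0.34 log units; beyond the scatter). The steps involving both limits cannot be read: the limit of > 20000 nM in this assay, at which 2 of the 4 values shown sit.

As far as these compounds go, it remains open whether chloro, a methyl group or an amine at this position would match bromo. From the compounds shown here alone, it is also open whether bromo would lower the number for the trifluoromethyl analogue, compound 2.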